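Methoxy for methyl on the sulfonate ring of compound 3

The compounds below may be only part of what the source reports. "The series", "measured", "known", "first", "only" and "open" are said of these compounds alone.

Measured so far:
compound 1, `Cc1ccc(S(=O)(=O)Oc2ccccc2/C=C(\C#N)C(=O)Nc2nnc(Cc3ccc(Cl)cc3)s2)cc1`, in a functional assay on RS4-11 cells (Homo sapiens) for inhibition, read by CCK-8 assay, with a stated time of 48 h, tested at 20 uM (a higher number here means more inhibition of growth at the concentration tested, a lower number less inhibition of growth), compound 1 gives 69%.
compound 2, `COc1ccc(S(=O)(=O)Oc2ccccc2/C=C(\C#N)C(=O)Nc2nnc(Cc3ccc(Cl)cc3)s2)cc1`, in this assay compound 2 gives 77%.
compound 3, `Cc1ccc(Cc2nnc(NC(=O)/C(C#N)=C/c3ccccc3OS(=O)(=O)c3ccc(C)cc3)s2)cc1`, in this assay compound 3 gives 66%.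

Compound 1 and compound 2 differ by methoxy in place of methyl on an aromatic carbon, and this change made a step of a number 8 percentage points higher from compound 1 to compound 2 (within the scatter). The cores of compound 1 and compound 3 differ by methyl in place of chloro on an aromatic carbon, with a step of a number 3 percentage points lower from compound 1 to compound 3 (within the scatter). Compound 3 has the lowest of the three numbers, though compound 1 stands within the scatter of it.

Compound 4, `COc1ccc(S(=O)(=O)Oc2ccccc2/C=C(\C#N)C(=O)Nc2nnc(Cc3ccc(C)cc3)s2)cc1`, has not yet been measured. It differs from compound 3 by methoxy in place of methyl on an aromatic carbon, the same change that turns compound 1 into compound 2, at the same place. Because the step of a number 8 percentage points higher from compound 1 to compound 2 (within the scatter) stayed within the scatter, the step from compound 3 to compound 4 is expected to be of similar size, a number 8 percentage points higher from compound 3 to compound 4 (within the scatter), and it may equally fall to nothing. On this basis compound 4 is estimated to give 74% in this assay, with a likely range from 62% to 84%.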

Compound 4, percent growth inhibition at one concentration: 79%
Estimate against measurement, compound 4: 5 percentage points below; measured number inside the range.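

In this assay the change from 4-methylphenyl to 4-methoxyphenyl gave a number 13 percentage points higher from compound 3 to compound 4 (beyond the scatter), and the two cores do not differ measurably in how they take this change: the same change on two cores in this assay, a number 8 percentage points higher (within the scatter) from compound 1 to compound 2 and a number 13 percentage points higher (beyond the scatter) from compound 3 to compound 4, 5 percentage points apart, within the scatter of two such steps. The exchange of chloro for methyl gave a number 2 percentage points higher from compound 2 to compound 4 (within the scatter), and it too reads alike on both cores: the same change on two cores in this assay, a number 3 percentage points lower (within the scatter) from compound 1 to compound 3 and a number 2 percentage points higher (within the scatter) from compound 2 to compound 4, 5 percentage points apart, within the scatter of two such steps. This shows that the methoxy change carried from one core to a second that differs from it in a single group, but two cores do not fix the size of the step, as one step lies within the scatter and the other beyond it, and they say nothing about more distant cores.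

The compounds shown leave open what an ethoxy group, an amine or a carboxylic acid would do in place of the methoxy. They also leave open whether the step holds on a core bearing a group other than methyl or chloro, such as trifluoromethyl.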